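Methacrylamide in place of acetamide on the trimethoxyphenyl core

This account rests on a few compounds, and the source may have more. Where it says the series, first, only, none or still open, it means among the compounds named here.

Compound 1 `COc1ccc(CN(C(C)=O)c2cc(OC)c(OC)c(OC)c2)cc1O` holds the lower of the two numbers in hand in a functional assay on KYSE-450 cells (Homo sapiens) for inhibition, read by MTT assay, with a stated time of 48 h (a higher number here means a weaker inhibitor, a lower number a stronger inhibitor), giving 160 nM. Going by the values given here, compound 2 `COc1ccc(CNc2cc(OC)c(OC)c(OC)c2)cc1Cl` gives 47800 nM in this assay, a gap far beyond the scatter, though no single-point step links the two. Compound 3 `C=C(C)C(=O)N(Cc1ccc(OC)c(O)c1)c1cc(OC)c(OC)c(OC)c1` differs from compound 1 in one place: 1-methylethenyl in place of methyl on a carbonyl carbon. With the shared core and the amide-type nitrogen unchanged, a small step, within the scatter or a little weaker, is expected: a 1.4-fold higher number from compound 1 to compound 3 (0.14 log units; within the scatter). For compound 3 the expected value in this assay is 220 nM, with a range from 60 nM to 900 nM.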

Compound 3, half-maximal inhibitory concentration: 200 nM
Beside the measured number, compound 3's estimate is 1.1-fold (0.04 log units) above it; measured number inside the range.
By their numbers in this assay, from the lowest: compounds 1 and 3 (each within the scatter of the next); then compound 2.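

In this assay, the step of a 1.3-fold higher number from compound 1 to compound 3 (0.10 log units; within the scatter) shows that this position on the carbonyl carbon accepts 1-methylethenyl in place of methyl, a larger group with a double bond outside aromatic rings, with no change beyond the scatter. The earlier compounds shown here offered no single-place comparison at this position. No data on hand account for this tolerance.

On these data alone, whether a longer chain, a phenyl ring or a carboxylic acid on this carbonyl carbon would also hold the number remains open. So does the separate contribution of the acetyl group, as compound 2 differs from compound 1 in more than one place.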